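Benzyl ester amides of a shared core: tail flick notes

The source may hold more compounds than are shown below. What is called first, only, known or untested is meant among the compounds shown, and "the series" means these compounds.

compound 1 `O=C(CN(c1nc(Cl)nc2[nH]cnc12)C1CC1)N[C@@H](CO)C(=O)OCc1ccccc1` — 31.9%
compound 2 `O=C(OCc1ccccc1)[C@@H]1CCCN1C(=O)CN(c1nc(Cl)nc2[nH]cnc12)C1CC1` — 33.2%

In a functional assay on the whole organism (Tail, strain ICR) with Mus musculus as the target, in the tail flick test, with a stated time of 30 min, at a dose of 25 umol/kg by the oral route (a higher number here means a stronger effect of the compound at the dose given, a lower number a weaker effect), compound 1 gives 31.9%, the lower of the two numbers, and compound 2 gives 33.2%, a gap within the scatter, so no order is read between them. Compound 3 `C[C@@H](O)[C@H](NC(=O)CN(c1nc(Cl)nc2[nH]cnc12)C1CC1)C(=O)OCc1ccccc1` is not yet measured; it differs from compound 1 in one place: methyl in place of hydrogen on a saturated chain carbon bound to an oxygen on a saturated carbon and a saturated chain carbon. For the measured compounds named here, no step between measured compounds is known, so only the two values above guide the expectation. The step of a number 0.1 percentage points higher from compound 1 to compound 3 (within the scatter) is expected to stay within the scatter. Compound 3 is expected to give 32% in this assay, between 18% and 46%.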

Compound 3, a percentage reported as activity, at one dose (the size of the read-out at that dose, not a potency): 21.9%
For compound 3 the middle estimate is 10.1 percentage points above the measured one; the measured number falls inside the stated range.
By their numbers in this assay, from the lowest: compounds 3, 1 and 2 (each within the scatter of the next, the first and the last beyond it).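

In this assay, for the compounds shown here, the change from hydroxymethyl to 1-hydroxyethyl gives a number 10 percentage points lower from compound 1 to compound 3 (within the scatter), the only step available at this position. At this single dose, adding methyl on this saturated chain carbon therefore does not separate the two compounds. No measurement on hand bears on a cause for this step.

On these data alone, whether a longer chain such as 1-hydroxypropyl, or an amine or carboxylic acid in place of the hydroxyl, would move the read-out beyond the scatter remains open. An ethyl group in place of 1-hydroxyethyl would test whether the hydroxyl matters here.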